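The source may hold more compounds than are shown below. What is called first, only, known or untested is meant among the compounds shown, and "the series" means these compounds.

In an ADME assay on MT4 cells (Homo sapiens) for cytotoxicity, read by MTT assay (a higher number here means that more compound is tolerated, a lower number that less compound is tolerated), compound 1 `O=C1c2ccccc2C(=O)N1CCOC(=S)N(C(=O)c1ccc(Cl)c([N+](=O)[O-])c1)c1ccccc1` gives 51000 nM, compound 2 `O=C1c2ccccc2C(=O)N1CCOC(=S)N(C(=O)c1cc(F)cc(F)c1)c1ccc(Cl)cc1` gives 59000 nM and compound 3 `O=C1c2ccccc2C(=O)N1CCOC(=S)N(C(=O)c1cc([N+](=O)[O-])ccc1Cl)c1ccc(Cl)cc1` gives 45000 nM. These three numbers lie within the scatter of each other, so compound 3 stands level with the other two. Compound 4 `O=C1c2ccccc2C(=O)N1CCOC(=S)N(C(=O)c1ccc(Cl)c([N+](=O)[O-])c1)c1ccc(Cl)cc1` arises from compound 3 by a single change: 4-chloro-3-nitrophenyl in place of 2-chloro-5-nitrophenyl on a carbonyl carbon. For the measured compounds named here, the one measured step at this carbonyl carbon, a 1.3-fold lower number from compound 2 to compound 3 (0.12 log units; within the scatter), stayed within the scatter. Compound 4 differs elsewhere from compound 1, which carries the same 4-chloro-3-nitrophenyl group and gives 51000 nM. No step beyond the scatter is therefore expected. The estimate is a 1.1-fold higher number from compound 3 to compound 4 (0.04 log units; within the scatter). For compound 4 the expected value is 49000 nM, with an estimated range of 29000 nM to 82000 nM.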

Compound 4, half-maximal cytotoxic concentration: 48000 nM
Compound 4: the middle estimate sits 1.0-fold (0.01 log units) above what was measured; the measured number falls inside the stated range.
By their numbers in this assay, from the lowest: compounds 3, 4, 1 and 2 (each within the scatter of the next).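

In this assay, 4-chloro-3-nitrophenyl in place of 2-chloro-5-nitrophenyl on a carbonyl carbon gives a 1.1-fold higher number from compound 3 to compound 4 (0.03 log units; within the scatter) and in place of 3,5-difluorophenyl gives a 1.2-fold lower number from compound 2 to compound 4 (0.09 log units; within the scatter), so all three groups at this carbonyl carbon stand level. Chloro in place of hydrogen on an aromatic carbon adds a second kind of change, with a 1.1-fold lower number from compound 1 to compound 4 (0.03 log units; within the scatter) as its step. No evidence here bears on these results. Still open, on these data alone, is whether an amine or a carboxylic acid on the aromatic ring at this carbonyl carbon would give a step beyond the scatter in this assay.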